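The compounds below may be only part of what the source reports. "The series", "measured", "known", "first", "only" and "open" are said of these compounds alone.

Of the compounds shown here, three sharing one core have been measured in an ADME assay on HEK293 cells (Homo sapiens) for cytotoxicity, read by sulforhodamine B assay, with a stated time of 48 h, tested at 10 uM; a lower number here means less inhibition, a higher number more inhibition at the concentration tested (going by the name of the read-out). Compound 1 `COc1nc2ccc(Br)cc2cc1C(c1ccccc1)n1cc(-c2ccc(Br)cc2)nn1` gives 6.28%, compound 2 `CCCCCCc1cn(C(c2ccccc2)c2cc3cc(Br)ccc3nc2OC)nn1` gives -3.17%, and compound 3 `COc1nc2ccc(Br)cc2cc1C(c1ccccc1)n1cc(-c2ccccc2)nn1` gives 8.25%. Compound 3 holds the highest of the three numbers, though compound 1 sits within the scatter of it; only compound 2 lies clearly apart, since a number 11.4 percentage points higher from compound 2 to compound 3 (beyond the scatter). Compound 4 `CCCCc1cn(C(c2ccccc2)c2cc3cc(Br)ccc3nc2OC)nn1` differs from compound 3 in one place: butyl in place of phenyl on an aromatic carbon. Among the compounds with values here, two measured steps bear on this. The step from hexyl to phenyl just named runs the opposite way, and a number 9.5 percentage points lower from compound 1 to compound 2 (within the scatter). Both suggest a lower number when a chain replaces phenyl, so a modest drop in this assay is expected, a number 8.3 percentage points lower from compound 3 to compound 4 (within the scatter). Compound 4 is therefore estimated at 0%, with a range from -12% to 12%.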

Compound 4, a percentage reported as inhibition, at one concentration (the size of the read-out at that concentration, not a potency): -3.47%
Estimate against measurement, compound 4: 3.5 percentage points above, within the range that was stated.
By their numbers in this assay, from the lowest: compounds 4, 2, 1 and 3 (each within the scatter of the next, the first and the last beyond it).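

On this aromatic carbon, butyl and hexyl cannot be told apart in this assay, with a number 0.3 percentage points lower from compound 2 to compound 4 (within the scatter) as the step between them. Swapping phenyl for butyl gives a clear but modest change, with a number 11.7 percentage points lower from compound 3 to compound 4 (beyond the scatter) beyond the scatter, yet swapping 4-bromophenyl for butyl does not, with a number 9.8 percentage points lower from compound 1 to compound 4 (within the scatter) within it, so the separation between chain and aromatic ring holds only against phenyl. No supporting data explain this difference. As far as these compounds go, whether a methyl group, a longer chain or a chain ending in an amine would match butyl remains open.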